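A Longer Chain for Compound 4

The compounds below may be only part of what the source reports. "The series", "measured", "known", "first", "only" and "open" are said of these compounds alone.

In a functional assay on microsomes from liver (Rattus norvegicus, strain Wistar) for inhibition, with a stated time of 1 h (on this read-out higher numbers stand for weaker inhibition and lower numbers for stronger inhibition), compound 1 (`CCCC(=O)OCC1Oc2ccc([C@H]3Oc4cc(O)cc(O)c4C(=O)[C@@H]3O)cc2OC1c1ccc(O)c(OC)c1`) gives 91700 nM, compound 2 (`CCCCCCCCC(=O)OCC1Oc2ccc([C@H]3Oc4cc(O)cc(O)c4C(=O)[C@@H]3O)cc2OC1c1ccc(O)c(OC)c1`) gives 61100 nM, and compound 3 (`CCCCCCCCCCCC(=O)OCC1Oc2ccc([C@H]3Oc4cc(O)cc(O)c4C(=O)[C@@H]3O)cc2OC1c1ccc(O)c(OC)c1`) gives 50500 nM. Compound 3 therefore stands within the usual scatter of both others. Compound 4 (`CCCCCCCCCCCCCCCC(=O)OCC1Oc2ccc([C@H]3Oc4cc(O)cc(O)c4C(=O)[C@@H]3O)cc2OC1c1ccc(O)c(OC)c1`) differs from it by butyl in place of hydrogen on a saturated chain carbon, ten or more bonds along the chain from a carbonyl carbon. The three measured chain changes bear on this: a 1.5-fold lower number from compound 1 to compound 2 (0.18 log units; within the scatter), a 1.2-fold lower number from compound 2 to compound 3 (0.08 log units; within the scatter) and a 1.8-fold lower number from compound 1 to compound 3 (0.26 log units; within the scatter). None goes beyond the scatter, so no clear shift is expected in this assay here. The expected step is a 1.1-fold lower number from compound 3 to compound 4 (0.05 log units; within the scatter). Compound 4 is estimated at 45000 nM, with an expected range from 22000 nM to 95000 nM.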

Compound 4, half-maximal inhibitory concentration: 51900 nM
Compound 4: middle estimate off by 1.2-fold (0.06 log units), on the low side; the measured number falls inside the stated range.
By their numbers in this assay, from the lowest: compounds 3, 4, 2 and 1 (each within the scatter of the next).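

Adding butyl on a saturated chain carbon gives a 1.0-fold higher number from compound 3 to compound 4 (0.01 log units; within the scatter) in this assay so lengthening the chain this far out makes no readable difference. With a 1.2-fold lower number from compound 2 to compound 4 (0.07 log units; within the scatter) and a 1.8-fold lower number from compound 1 to compound 4 (0.25 log units; within the scatter) as well, even the largest chain addition here stays within the scatter, and these four compounds show no clear effect of chain length. No supporting measurement is available to explain this flat result. Going by these compounds, whether a still longer chain would shift the number beyond the scatter remains open. So does the effect of an amine or a carboxylic acid in place of the butyl.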